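Swapping the aryl group on the core of compound 2

This account rests on a few compounds, and the source may have more. Where it says the series, first, only, none or still open, it means among the compounds named here.

The measured compounds are compound 1 `COc1cc(/C=C/C(=O)C2=C(/C=C/c3ccc(O)c(OC)c3)NC(=O)NC2c2ccc(C)cc2)ccc1O` with 52.2%, compound 2 `COc1cc(/C=C/C(=O)C2=C(/C=C/c3ccc(O)c(OC)c3)NC(=O)NC2c2ccc(N(C)C)cc2)ccc1O` with 89.2%, and compound 3 `COc1cc(/C=C/C(=O)C2=C(/C=C/c3ccc(O)c(OC)c3)NC(=O)NC2c2cccc([N+](=O)[O-])c2)ccc1O` with 48%, all in a functional assay, with a stated time of 20 min, tested at 50 uM; a higher number here means a stronger effect of the compound at the concentration tested, a lower number a weaker effect.

Compound 2 gives the highest number of the three; both other values lie beyond the scatter below it. Compound 4 `COc1cc(/C=C/C(=O)C2=C(/C=C/c3ccc(O)c(OC)c3)NC(=O)NC2c2ccccc2Cl)ccc1O` differs from compound 2 by 2-chlorophenyl in place of 4-(dimethylamino)phenyl on a saturated ring carbon. The two changes at the same saturated ring carbon give a number 37 percentage points higher from compound 1 to compound 2 (beyond the scatter) and a number 41.2 percentage points lower from compound 2 to compound 3 (beyond the scatter): each time the 4-(dimethylamino)phenyl group is absent, this assay reads far lower. Compound 4 is therefore expected to lose strongly, estimated as a number 39.2 percentage points lower from compound 2 to compound 4 (beyond the scatter). For compound 4 the expected value is 50%, with a range from 35% to 65%.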

Compound 4, a percentage reported as activity, at one concentration (the size of the read-out at that concentration, not a potency): 56%
For compound 4 the middle estimate is 6 percentage points below the measured one; low and high end bracket the measured number.
By their numbers in this assay, from the lowest: compounds 3, 1 and 4 (each within the scatter of the next); then compound 2.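

In this assay a third replacement on the saturated ring carbon, 2-chlorophenyl, also falls far short of 4-(dimethylamino)phenyl (a number 33.2 percentage points lower from compound 2 to compound 4 (beyond the scatter)), so among the four compounds only compound 2 stands apart. The three lower compounds do not separate, although their groups differ in substituent and ring placement (a number 8 percentage points higher from compound 3 to compound 4 (within the scatter); a number 3.8 percentage points higher from compound 1 to compound 4 (within the scatter)). No measurement shown gives a reason for this. On these data alone, it remains open whether the high reading is specific to the dimethylamino group or would persist with a primary amine, a diethylamino group or a morpholine ring on the aromatic ring.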